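The compounds below may be only part of what the source reports. "The series", "measured", "known", "first", "only" and "open" are said of these compounds alone.

In a functional assay on PC-3 cells (Homo sapiens) for antiproliferative activity, read by MTT assay, with a stated time of 72 h (a lower number here means a stronger inhibitor, a higher number a weaker inhibitor), compound 2 `O=C(O)CCCC(=O)OCCCOc1no[n+]([O-])c1S(=O)(=O)c1ccccc1` gives 3300 nM, the lower of the two actual numbers in this set. Compound 3 `O=C(O)c1ccccc1C(=O)OCCOc1no[n+]([O-])c1S(=O)(=O)c1ccccc1` gives 9900 nM, a higher number by a gap beyond the scatter. Compound 1 `O=C(O)CCC(=O)OCCCOc1no[n+]([O-])c1S(=O)(=O)c1ccccc1` gives > 10000 nM, which is a limit of the assay and not a number. Compound 4 `O=C(O)c1ccccc1C(=O)OCCCOc1no[n+]([O-])c1S(=O)(=O)c1ccccc1` has not yet been measured. It differs from compound 2 in one place: 2-carboxyphenyl in place of 3-carboxypropyl on a carbonyl carbon. In words, 2-carboxyphenyl stands in place of 3-carboxypropyl on a carbonyl carbon. Among the measured compounds shown here, the one measured step in this part of the structure, an at least 3.0-fold lower number from compound 1 to compound 2 (0.48 log units; beyond the scatter), lies beyond the scatter, so the number does respond to change here. For the measured compounds named here, no measured step makes this exact exchange, but compound 3 also carries 2-carboxyphenyl on a carbonyl carbon and gives 9900 nM. A modest move to a higher number is therefore expected in this assay. The estimated step is a 2.1-fold higher number from compound 2 to compound 4 (0.33 log units; beyond the scatter). For compound 4 the expected value is 7000 nM, with an estimated range of 2500 nM to 20000 nM.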

Compound 4, half-maximal inhibitory concentration: 4900 nM
For compound 4 the middle estimate is 1.4-fold (0.15 log units) above the measured one, within the range that was stated.
By their numbers in this assay, from the lowest: compounds 2 and 4 (each within the scatter of the next); then compound 3. At a limit, above all of these: compound 1.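

In this assay the exchange of 3-carboxypropyl for 2-carboxyphenyl on this carbonyl carbon stays inside the scatter, a 1.5-fold higher number from compound 2 to compound 4 (0.17 log units; within the scatter), so the open chain and the six-membered aromatic ring cannot be told apart here. Compound 1 gives no number, only a limit of the assay: the limit of > 10000 nM in this assay, at which 1 of the 4 values shown sits. The step of an at least 2.0-fold lower number from compound 1 to compound 4 (0.30 log units; that floor lies within the scatter) therefore sets only a floor, while compound 3, which also carries 2-carboxyphenyl on a carbonyl carbon, gives 9900 nM, so that group alone does not fix the number.

Going by these compounds, what a plain phenyl or an amine on this carbonyl carbon would give, in place of a group carrying a carboxylic acid, stays open. So does the reading of a longer chain than 3-carboxypropyl at this place.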